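Swapping a Benzyl Bridge for an Anilino Linker

The source may report more compounds than this note shows. Statements on the series, on what has been measured and on what is new or still open speak of the compounds shown alone.

Within the data shown here, compound 2 `C[C@@H](NCc1ccc(Cc2ccccc2)cc1)C(N)=O` gives 15.7 mg/kg in a functional assay on the whole organism with Mus musculus as the target (a higher number here means that more compound is needed for the effect, a lower number that less compound is needed), the lower of the two numbers so far. Compound 1 `CCCCC(C)NCC(N)=O` gives 640 mg/kg in this assay, and the gap between them lies beyond the usual scatter. Compound 3 `C[C@@H](NCc1ccc(CNc2ccccc2)cc1)C(N)=O` has not yet been measured; it differs from compound 2 by anilino in place of phenyl on a saturated chain carbon bound to an aromatic carbon. Among the measured compounds shown here, no step of this kind has been measured among the compounds here, so the expected step is a 1.4-fold higher number from compound 2 to compound 3 (0.15 log units; within the scatter), small and, if anything, toward a somewhat higher dose. Compound 3 is estimated to give 22 mg/kg in this assay, within 8 mg/kg to 60 mg/kg.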

Compound 3, dose for half-maximal effect: 119 mg/kg
The estimate for compound 3 lay 5.4-fold (0.73 log units) below the measured number, outside the stated range (above it).
By their numbers in this assay, from the lowest: compound 2; then compound 3; then compound 1.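

Among these compounds, replacing phenyl with anilino on a saturated chain carbon bound to an aromatic carbon gives a 7.6-fold higher number from compound 2 to compound 3 (0.88 log units; beyond the scatter) in this assay and is the first single-place comparison here. It shows that this position is sensitive to the exchange, and that the change raises the dose needed for the effect. No available evidence bears on the reason for this step.

The compounds shown leave open whether phenoxy or N-methylanilino at this position would stay close to compound 2 or follow compound 3. They also leave open how substituents on the anilino ring would alter the number.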